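Silyl ether on the hydroxyl of compound 1

This account rests on a few compounds, and the source may have more. Where it says the series, first, only, none or still open, it means among the compounds named here.

Values in an ADME assay on KB cells (Homo sapiens) for cytotoxicity, read by MTT assay, with a stated time of 72 h; on this read-out lower numbers stand for stronger inhibition and higher numbers for weaker inhibition:
- compound 1 `COc1ccc(C2=C(c3cc(OC)c(OC)c(OC)c3)CC(O)C2=O)cc1[N+](=O)[O-]`: > 100 ug/mL (a limit, not a number)
- compound 2 `COc1ccc(C2=C(c3cc(OC)c(OC)c(OC)c3)C(=O)C(O)C2)cc1F`: 4.5 ug/mL
- compound 3 `COc1ccc(C2=C(c3cc(OC)c(OC)c(OC)c3)C(=O)C(OC(C)=O)C2)cc1Cl`: 64 ug/mL

Compound 1 has no numerical value, only a limit: the limit of > 100 ug/mL in this assay, at which 1 of the 3 values shown sits.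

Compound 4 `COc1ccc(C2=C(c3cc(OC)c(OC)c(OC)c3)CC(O[SiH2]C(C)(C)C)C2=O)cc1[N+](=O)[O-]` is not yet measured. It differs from compound 1 by a single change: a group of 5 heavy atoms (4 carbon, 1 silicon; no ring) in place of a hydrogen atom, on an oxygen on a saturated carbon.

Within the data shown here, no measured pair isolates this change. Among the measured compounds shown here, compound 3, with an acetylated oxygen, gives 64 ug/mL, and compound 2, with a free hydroxyl, gives 4.5 ug/mL, but these two differ in more than one place and define no step.

In this assay, capping the oxygen of compound 1 is expected to produce no step beyond the scatter, and no direction is assumed. The estimated at least 1.4-fold lower number from compound 1 to compound 4 (0.15 log units; that floor lies within the scatter) is therefore only a rough expectation. Compound 4 is estimated at 70 ug/mL, with an expected range of 20 ug/mL to 200 ug/mL.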

Compound 4, half-maximal inhibitory concentration: > 100 ug/mL
Compound 4: a limit, no number; the forecaster's own chance of this, stated with the estimate: 40%; middle value at least 1.4-fold (0.15 log units) from the limit.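

Compound 1 and compound 4 both stand only as limits in this assay, so no step can be read between them: the limit of > 100 ug/mL in this assay, at which 2 of the 4 values shown sit.

The compounds shown leave open whether the silyl ether changes the read-out at all relative to the free hydroxyl of compound 1.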